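This account rests on a few compounds, and the source may have more. Where it says the series, first, only, none or still open, it means among the compounds named here.

Measured compounds:
Compound 1, `Nc1nc(O)c2c(n1)n(C1OC(CO)[C@@H](O)[C@H]1O)c(=O)n2Cc1ccc(Cl)c(Cl)c1`, in a functional assay on the whole organism (B cells) with Mus musculus as the target; a lower number here means a smaller maximal response, a higher number a larger maximal response: compound 1 gives 55%.
Compound 2, `C=CCn1c(=O)n([C@H]2CO[C@@H](CO)C2)c2nc(N)nc(O)c21`, in this assay: compound 2 gives 10%.

Of these two numbers, compound 1 stands highest. Its nearest neighbour is compound 2, whose maximal response lies well below, beyond the scatter. The two differ in more than one place, so their gap cannot be read as a single step.

The account now turns to compound 3, `CCOC(=O)Cn1c(=O)n(C2OC(CO)[C@@H](O)[C@H]2O)c2nc(N)nc(O)c21`, which has not been measured in this assay. Compound 3 is derived from compound 1 by one change: ethoxycarbonyl in place of 3,4-dichlorophenyl on a saturated chain carbon bound to an aromatic nitrogen. In other words, the 3,4-dichlorobenzyl of compound 1 becomes (ethoxycarbonyl)methyl.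

The only other point of reference, compound 2, also lacks the 3,4-dichlorophenyl and gives 10%, so a fall is the more likely direction. Compound 3 is therefore expected to give about 25% in this assay, between 5% and 50%. This corresponds to an expected downward step of a number 30 percentage points lower from compound 1 to compound 3 (beyond the scatter), larger than the scatter.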

Compound 3, largest response reached (reported as maximal response), in percent of the reference or control that the assay uses: 86%
For compound 3 the middle estimate is 61 percentage points below the measured one; the measured number lies above the stated range.
By their numbers in this assay, from the lowest: compound 2; then compound 1; then compound 3.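

In this assay, the maximal response comes out a number 31 percentage points higher from compound 1 to compound 3 (beyond the scatter) when ethoxycarbonyl takes the place of 3,4-dichlorophenyl on a saturated chain carbon bound to an aromatic nitrogen. The 3,4-dichlorophenyl is therefore not needed at this place for a response in this assay: on the same core, an ethoxycarbonyl with no ring and two hydrogen-bond acceptors gives a larger maximal response than a ring with none. Nothing measured among these compounds explains why the response rises with this change.

The compounds shown do not tell whether the ester is what matters, since a carboxylic acid, a primary amide or a plain propyl chain at the same place does not appear among them. They also do not separate the aromatic ring from its two chlorines, as an unsubstituted benzyl is absent, and the whole reading of this position rests on one pair of compounds in a single assay.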